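Working notes: bromo in place of methyl in compound 1

This account rests on a few compounds, and the source may have more. Where it says the series, first, only, none or still open, it means among the compounds named here.

- compound 1 `Cc1ccc(CN2CCC=C(CCC(=O)NO)C2=O)cc1` gives 5000 nM
- compound 2 `Cc1ccc(S(=O)(=O)Nc2ccc(CN3CCC=C(CCC(=O)NO)C3=O)cc2)cc1` gives 370 nM

In a functional assay on ACHN cells (Homo sapiens) for inhibition, read by sulforhodamine B assay (on this read-out higher numbers stand for weaker inhibition of growth and lower numbers for stronger inhibition of growth), compound 1 holds the higher of the two numbers, and compound 2 lies lower, beyond the scatter. Compound 3 `O=C(CCC1=CCCN(Cc2ccc(Br)cc2)C1=O)NO` differs from compound 1 by bromo in place of methyl on an aromatic carbon, para to a large group (bromo in place of methyl on an aromatic carbon). Going by the values given here, no measured pair covers this change, and in this assay no step beyond the scatter is expected. The estimated change is small (a 1.3-fold lower number from compound 1 to compound 3 (0.10 log units; within the scatter)). Compound 3 is expected at 4000 nM (estimated range 1500 nM to 10000 nM).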

Compound 3, concentration for 50% growth inhibition: 2480 nM
For compound 3 the middle estimate is 1.6-fold (0.21 log units) above the measured one; low and high end bracket the measured number.
By their numbers in this assay, from the lowest: compound 2; then compounds 3 and 1 (each within the scatter of the next).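

In this assay the change from 4-methylphenyl to 4-bromophenyl gives a 2.0-fold lower number from compound 1 to compound 3 (0.30 log units; within the scatter) and so shows that this place on the aromatic ring, para to a large group, accepts bromo in place of methyl without a step beyond the scatter. Going by these compounds alone, the single pair covers only these two groups and only the core of compound 1. No supporting data explain this result.

On these data alone, whether an amine, a carboxylic acid or a methoxy group at this place would also stay within the scatter remains open. Also open, as far as these compounds go, is whether a fluoro or chloro group would behave like bromo here.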